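Cytotoxicity notes: aryl-to-cyclohexyl change on the shared core

The source may report more compounds than this note shows. Statements on the series, on what has been measured and on what is new or still open speak of the compounds shown alone.

Measured so far:
- compound 1 `c1ccc(-c2ccc3c(NCCCNCc4ccco4)ccnc3c2)cc1`, 5920 nM
- compound 2 `COc1ccc(-c2ccc3c(NCCCNCc4ccco4)ccnc3c2)cc1`, 6000 nM
- compound 3 `CC(C)(C)c1ccc(-c2ccc3c(NCCCNCc4ccco4)ccnc3c2)cc1`, 3150 nM

All three were read in an ADME assay on HepG2 cells (Homo sapiens) for cytotoxicity, read by luminescence, CellTiter-Glo and ATP content, with a stated time of 72 h; on this read-out higher numbers stand for an effect only at larger amounts of compound and lower numbers for an effect already at smaller amounts. The steps among them stay small: a 1.0-fold higher number from compound 1 to compound 2 (0.01 log units; within the scatter), a 1.9-fold lower number from compound 1 to compound 3 (0.27 log units; within the scatter), a 1.9-fold lower number from compound 2 to compound 3 (0.28 log units; within the scatter). Compound 3 holds the lowest number of the three, but its steps to compound 1 and to compound 2 are within the scatter, so no order among the three can be claimed.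

Compound 4 `c1coc(CNCCCNc2ccnc3cc(C4CCCCC4)ccc23)c1` is not yet measured. It differs from compound 3 in one place: cyclohexyl in place of 4-(tert-butyl)phenyl on an aromatic carbon. Among the compounds with values here, none of the measured steps covers this change; the measured steps only vary the substituent on the 4-(tert-butyl)phenyl group and all lie within the scatter. With nothing in the data pointing either way, the expected step is none beyond the scatter: compound 4 is expected at a 1.4-fold higher number from compound 3 to compound 4 (0.15 log units; within the scatter) from compound 3. Within the data shown here, the estimate for compound 4 in this assay is therefore 4500 nM, with a range from 1500 nM to 13000 nM, kept wide because no measured step informs the change.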

Compound 4, half-maximal effective concentration: 4760 nM
For compound 4 the middle estimate is 1.1-fold (0.02 log units) below the measured one; low and high end bracket the measured number.
By their numbers in this assay, from the lowest: compounds 3, 4, 1 and 2 (each within the scatter of the next).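

Read in this assay, the change from an aromatic ring to cyclohexyl on this aromatic carbon gives a 1.5-fold higher number from compound 3 to compound 4 (0.18 log units; within the scatter) and a 1.3-fold lower number from compound 2 to compound 4 (0.10 log units; within the scatter) and a 1.2-fold lower number from compound 1 to compound 4 (0.09 log units; within the scatter) as its three steps, so each stays within the scatter. The earlier compounds shown here varied only the substituent on a phenyl ring, whereas these steps replace the aromatic ring itself with a non-aromatic ring of carbon only, and the read-out does not separate the two ring types in these four compounds. Nothing available here bears on what lies behind these numbers.

All four numbers sit within the scatter of their listed neighbours, so this position has not yet shown a step beyond it. Open, going by these compounds, is whether an amine, a carboxylic acid or a longer chain on this aromatic carbon, in place of the ring, would give such a step.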